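Amide-to-enaminone swap on the pyrrolidine nitrogen

The source may report more compounds than this note shows. Statements on the series, on what has been measured and on what is new or still open speak of the compounds shown alone.

Compound 1 `C[C@@H](O[C@@H]1CN(C=O)C[C@H]1c1ccc(F)cc1)c1cc(C(F)(F)F)cc(C(F)(F)F)c1` gives 0.24 nM in an assay on CHO cells for displacement of a labelled ligand from Substance-P receptor (Homo sapiens); on this read-out higher numbers stand for weaker inhibition and lower numbers for stronger inhibition. Compound 2 `C[C@@H](O[C@@H]1CN(C(=O)C(C)(C)C)C[C@H]1c1ccccc1)c1cc(C(F)(F)F)cc(C(F)(F)F)c1` gives 0.18 nM in this assay, and compound 3 `C[C@@H](O[C@@H]1CN(C(=O)N2CCOCC2)C[C@H]1c1ccccc1)c1cc(C(F)(F)F)cc(C(F)(F)F)c1` gives 0.16 nM; none of the three values departs from another beyond the scatter, so compound 3 sits among equals rather than apart from them. Going by the values given here, the one single-point step among them, a 1.1-fold lower number from compound 2 to compound 3 (0.05 log units; within the scatter), is flat.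

Compound 4 `C[C@@H](O[C@@H]1CN(C2=CC(=O)CC2)C[C@H]1c1ccccc1)c1cc(C(F)(F)F)cc(C(F)(F)F)c1` is the next point. It differs from compound 3 by 3-oxocyclopent-1-en-1-yl in place of (morpholin-4-yl)carbonyl on an amine nitrogen in a ring. Among the compounds with values here, no measured step exchanges a carbonyl-linked group on that nitrogen for a ring joined directly through a carbon, so the only guide is that the formyl, tert-butylcarbonyl and morpholinylcarbonyl variants all land close together, which suggests the nitrogen substituent is tolerant but does not speak for a directly attached cyclopentenone. The expected change in this assay is a 2.8-fold higher number from compound 3 to compound 4 (0.45 log units; beyond the scatter), a modest move toward weaker inhibition. Compound 4 is estimated at 0.45 nM, with a range of 0.12 nM to 1.8 nM.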

Compound 4, half-maximal inhibitory concentration: 0.07 nM
For compound 4 the middle estimate is 6.4-fold (0.81 log units) above the measured one; measured number outside the range, below it.
By their numbers in this assay, from the lowest: compound 4; then compounds 3, 2 and 1 (each within the scatter of the next).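

On the amine nitrogen in a ring, a carbonyl link is not required: in this assay, 3-oxocyclopent-1-en-1-yl attached directly through a ring carbon gives a 2.3-fold lower number from compound 3 to compound 4 (0.36 log units; beyond the scatter) and a 2.6-fold lower number from compound 2 to compound 4 (0.41 log units; beyond the scatter). The formyl, tert-butylcarbonyl and morpholinylcarbonyl variants offered no comparison at this position that moved beyond the scatter, whereas these two steps show that the substituent here can shift the number, though only modestly and towards stronger inhibition. Nothing available accounts for the lower number in compound 4.

Open, going by these compounds, is whether the ring size and the ketone matter, which a six-membered 3-oxocyclohex-1-en-1-yl or a saturated cyclopentyl on that nitrogen would test. Also open, on these data alone, is whether a ring is needed at all, which an open-chain 3-oxobut-1-en-1-yl would address.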